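The source may hold more compounds than are shown below. What is called first, only, known or untested is meant among the compounds shown, and "the series" means these compounds.

Measured so far:
Compound 1, `O=c1[nH]c(=O)n(CCC(CO)CO)cc1C#CCc1ccccc1`, gives 63800 nM in a functional assay on HeLa cells (Homo sapiens) for antiproliferative activity, read by MTT assay, with a stated time of 72 h; a higher number here means a weaker inhibitor, a lower number a stronger inhibitor.
Compound 2, `O=c1[nH]c(=O)n(CCC(CO)CO)cc1C#CC1CC1`, gives > 100000 nM in this assay, which is a limit of the assay rather than a number.

Compound 2 therefore stands only at a limit here. Among the compounds with values here, the one measured step, an at least 1.5-fold higher number from compound 1 to compound 2 (0.19 log units; that floor lies within the scatter), sits within the usual scatter, and the limit of > 100000 nM in this assay, at which 1 of the 2 values shown sits, caps what compound 2 shows. Compound 3, `CC(C)(C)C#Cc1cn(CCC(CO)CO)c(=O)[nH]c1=O`, differs from compound 2 by tert-butyl in place of cyclopropyl on a triple-bonded carbon. With only a step ending at a limit to lean on, the step that the limit leaves unreadable from compound 2 to compound 3 is expected to be small, with no clear direction. Compound 3 is estimated at 120000 nM, within 50000 nM to 300000 nM.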

Compound 3, half-maximal inhibitory concentration: > 100000 nM
Compound 3 was reported as a limit; the forecaster's own chance of this, stated with the estimate: 70%; the middle value does not contradict the limit.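

In this assay compound 3 gives > 100000 nM, which is a limit of the assay and not a number, so the step from cyclopropyl to tert-butyl cannot be read. Changing benzyl to tert-butyl gives an at least 1.5-fold higher number from compound 1 to compound 3 (0.19 log units; that floor lies within the scatter). Of the three groups on this triple-bonded carbon, only benzyl now gives a number: the limit of > 100000 nM in this assay, at which 2 of the 3 values shown sit.

Still open, from the compounds shown here alone, is how much activity compound 2 and compound 3 really have. Also open, going by these compounds, is whether an amine or a carboxylic acid in place of tert-butyl on this carbon would give a number at all.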